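This account rests on a few compounds, and the source may have more. Where it says the series, first, only, none or still open, it means among the compounds named here.

Compound 1 `NC(=O)c1ncn2c(=O)n(-c3ccc([N+](=O)[O-])cc3)nnc12` gives < 0.0167 h (a limit of the assay)
Compound 2 `Cc1ccc(-n2nnc3c(C(N)=O)ncn3c2=O)cc1` gives 0.667 h

Among the compounds with values here, in an ADME assay for pharmacokinetics (on this read-out lower numbers stand for a shorter-lived compound and higher numbers for a longer-lived compound), compound 2 gives 0.667 h, the only number so far. Compound 1 sits at < 0.0167 h, which is a limit. Compound 3 `NC(=O)c1ncn2c(=O)n(-c3ccc(Cl)cc3)nnc12` differs from compound 2 by chloro in place of methyl on an aromatic carbon. Within the data shown here, the one measured step bearing on this is an at least 39-fold higher number from compound 1 to compound 2 (1.60 log units; beyond the scatter), with methyl in place of nitro on an aromatic carbon. A modest step to a lower number is therefore expected in this assay, far smaller than that one. The expected change is a 2.2-fold lower number from compound 2 to compound 3 (0.35 log units; beyond the scatter). For compound 3 the estimate is 0.3 h, with an expected range from 0.08 h to 0.7 h.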

Compound 3, half-life: 0.105 h
The estimate for compound 3 lay 2.9-fold (0.46 log units) above the measured number; the measured number falls inside the stated range.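

In this assay, the position on the aromatic carbon para to a large group proves sensitive even to an exchange of one heavy atom for one heavy atom: chloro in place of methyl gives a 6.4-fold lower number from compound 2 to compound 3 (0.80 log units; beyond the scatter). Chloro in place of nitro gives an at least 6.2-fold higher number from compound 1 to compound 3 (0.79 log units; beyond the scatter), which places chloro between the other two groups on this read-out. The true size of that step stays open, as compound 1 is held at a limit of the assay: the limit of < 0.0167 h in this assay, at which 1 of the 3 values shown sits.

The compounds shown leave open how an amine, a methoxy group or a longer alkyl chain at this position would compare with methyl. They also leave open whether the same order holds when the amide on the shared core is replaced.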